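A Chloro Swap at the Assay's Limit

This account rests on a few compounds, and the source may have more. Where it says the series, first, only, none or still open, it means among the compounds named here.

For the measured compounds named here, in a functional assay on MCF7 cells (Homo sapiens) for cytotoxicity, read by MTT assay, with a stated time of 48 h (a lower number here means a stronger inhibitor, a higher number a weaker inhibitor), compound 1 `COc1cc(C#N)ccc1OCc1nnc(-c2ccc(C)cc2)o1` gives 27100 nM, the only numerical value in this small set. Compound 2 `N#Cc1ccc(OCc2nnc(-c3ccccc3)o2)cc1F` reaches only a limit, > 50000 nM. Compound 3 `Cc1ccc(-c2nnc(COc3ccc(C#N)c(F)c3)o2)cc1` also reaches only a limit, > 50000 nM. Compound 3 therefore has no number of its own and stands with compound 2 at the limit of > 50000 nM in this assay, at which 2 of the 3 values shown sit.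

Compound 4 `N#Cc1ccc(OCc2nnc(-c3ccc(Cl)cc3)o2)cc1F` differs from compound 3 by chloro in place of methyl on an aromatic carbon, para to a large group, which is the change from 4-methylphenyl to 4-chlorophenyl: chloro in place of methyl on an aromatic carbon. Going by the values given here, the one measured step that bears on this change is a step that the two limits leave unreadable from compound 2 to compound 3, with methyl in place of hydrogen on an aromatic carbon. That step offers neither a size nor a direction, so no shift beyond the scatter is expected in this assay. The expected change is a number no higher from compound 3 to compound 4 (the limit leaves the size open). A reported limit is again the likeliest result. For compound 4 the estimated value is 50000 nM, with an expected range of 22000 nM to 110000 nM.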

Compound 4, half-maximal inhibitory concentration: 48300 nM
The estimate for compound 4 lay 1.0-fold (0.02 log units) above the measured number, within the range that was stated.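

In this assay compound 4 gives a number at this position, para to a large group, where hydrogen and methyl had yielded only limits of the assay. The change to chloro reads as an at least 1.0-fold lower number from compound 3 to compound 4 (0.01 log units; that floor lies within the scatter), and counted from hydrogen it reads as an at least 1.0-fold lower number from compound 2 to compound 4 (0.01 log units; that floor lies within the scatter). Both are only floors, so neither shows a real drop, and the step between the two earlier compounds stays unreadable, with each of them held at a limit: the limit of > 50000 nM in this assay, at which 2 of the 4 values shown sit.

Going by these compounds, how far compound 2 and compound 3 truly lie from compound 4 remains open, so the true size of either step is unknown. Also open, on these data alone, is what an amine or a carboxylic acid would do on this same aromatic carbon.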